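Swapping a Hydroxylated Chain for Cyclopentyl at the Amide

The source may hold more compounds than are shown below. What is called first, only, known or untested is meant among the compounds shown, and "the series" means these compounds.

Compound 1, `N=c1oc2ccc(Br)cc2cc1C(=O)NCC(O)CO`, gives 4% in an assay on HEK293 cells for displacement of a labelled ligand from adenosine receptor A2b (Homo sapiens), read by scintillation counting, with a stated time of 30 min, tested at 10 uM; a lower number here means less inhibition, a higher number more inhibition at the concentration tested (going by the name of the read-out).
Compound 2, `N=c1oc2ccc(Br)cc2cc1C(=O)NCCO`, gives 15% in this assay.
Compound 3, `CCC(CO)NC(=O)c1cc2cc(Br)ccc2oc1=N`, gives 4% in this assay.

All three share one core and differ only in the group on the amide-type nitrogen. Compound 3 stands level with compound 1 at the digits shown, and together the two give the lowest numbers of the three. Compound 2 is the only one set apart: the step of a number 11 percentage points lower from compound 2 to compound 3 (beyond the scatter) lies beyond the scatter, as does a number 11 percentage points higher from compound 1 to compound 2 (beyond the scatter), while no change at the digits printed from compound 1 to compound 3 (within the scatter) stays within it.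

The unmeasured compound 4, `N=c1oc2ccc(Br)cc2cc1C(=O)NC1CCCC1`, follows from compound 3 by cyclopentyl in place of 1-(hydroxymethyl)propyl on an amide-type nitrogen. Going by the values given here, two measured steps touch on this. Removing a hydroxymethyl from the chain, as in a number 11 percentage points higher from compound 1 to compound 2 (beyond the scatter), raised the number modestly; adding an ethyl to the chain, as in a number 11 percentage points lower from compound 2 to compound 3 (beyond the scatter), lowered it by the same modest amount. Nothing measured covers closing the chain into a ring or removing every hydroxyl at once. A small upward move, or none beyond the scatter, is the most that these steps support. For compound 4 the expected number in this assay is 12%, within 0% to 30%. The expected step is a number 8 percentage points higher from compound 3 to compound 4 (within the scatter).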

Compound 4, a percentage reported as inhibition, at one concentration (the size of the read-out at that concentration, not a potency): 28%
For compound 4 the middle estimate is 16 percentage points below the measured one; the range from low to high includes it.
By their numbers in this assay, from the lowest: compounds 1 and 3 (each within the scatter of the next); then compound 2; then compound 4.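

Going by these compounds alone, the group on the amide-type nitrogen can move the number in this assay further than the earlier compounds showed: the change to cyclopentyl brings a number 24 percentage points higher from compound 3 to compound 4 (beyond the scatter), along with a number 24 percentage points higher from compound 1 to compound 4 (beyond the scatter) and a number 13 percentage points higher from compound 2 to compound 4 (beyond the scatter). Among the compounds shown, the three chains that carry a hydroxyl all sit below the one group without a hydroxyl, a five-membered ring of carbon only with no hydrogen-bond donor or acceptor. This swap closes a ring and removes the hydroxyl in a single move, and the steps alone do not separate those two changes; nothing available gives a measured cause for the rise.

Still open, as far as these compounds go, is whether an open chain with no hydroxyl, such as butyl, would match the ring, and a cyclopentyl carrying a hydroxyl would test the same question from the other side. Also open, from the compounds shown here alone, is how a larger ring such as cyclohexyl, a flat ring such as phenyl, or an amine in this group would fare, and whether the stronger effect of compound 4, at 28% from a single concentration, would hold at other concentrations.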